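Dropping the Chlorines from the Sulfonyl Aryl Group

The source may hold more compounds than are shown below. What is called first, only, known or untested is meant among the compounds shown, and "the series" means these compounds.

Within the data shown here, compound 1 `CC1CCN(c2c(S(=O)(=O)c3cc(Cl)cc(Cl)c3)cnc3ccc(Cl)cc23)CC1` has the highest number of the three compounds measured so far: in an assay on isolated protein for displacement of a labelled ligand from metabotropic glutamate receptor 5 (Homo sapiens), with a stated time of 60 min, tested at 1 uM (on this read-out higher numbers stand for more inhibition at the one concentration tested (going by the name of the read-out) and lower numbers for less inhibition), compound 1 gives 88%. Compound 2 `CC1CCN(c2c(S(=O)(=O)c3cc(Cl)cc(Cl)c3)cnc3ccc(F)cc23)CC1` gives 69%, and compound 3 `O=S(=O)(c1ccc(F)cc1)c1cnc2cc(Cl)ccc2c1N1CCC(CO)CC1` gives 75%; both sit a step beyond the scatter below compound 1.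

Compound 4 `CC1CCN(c2c(S(=O)(=O)c3ccccc3)cnc3ccc(Cl)cc23)CC1` has not yet been measured. Its change from compound 1 is phenyl in place of 3,5-dichlorophenyl on a sulfonyl sulfur. Among the measured compounds shown here, only one measured step exists, a number 19 percentage points lower from compound 1 to compound 2 (beyond the scatter), and it concerns a halogen swap on the shared core, not the aryl group on the sulfonyl, so it bears only loosely on this change. Compound 3 carries a differently substituted aryl on its sulfonyl but differs from compound 1 in further places as well, so its value alone cannot isolate that effect. Stripping the chlorines from the sulfonyl aryl group is a larger change than the single halogen swap of a number 19 percentage points lower from compound 1 to compound 2 (beyond the scatter), so a downward step of similar or greater size is expected, a number 26 percentage points lower from compound 1 to compound 4 (beyond the scatter). Compound 4 is therefore estimated at 62%, within a range from 40% to 82%.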

Compound 4, a percentage reported as inhibition, at one concentration (the size of the read-out at that concentration, not a potency): 59%
Beside the measured number, compound 4's estimate is 3 percentage points above it; the range from low to high includes it.
By their numbers in this assay, from the lowest: compounds 4, 2 and 3 (each within the scatter of the next, the first and the last beyond it); then compound 1.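

In this assay, among these compounds, phenyl in place of 3,5-dichlorophenyl on a sulfonyl sulfur gives a number 29 percentage points lower from compound 1 to compound 4 (beyond the scatter), the first step that can be read at this place. Among the compounds shown here, the only earlier step, a number 19 percentage points lower from compound 1 to compound 2 (beyond the scatter), changed a halogen on the shared core, so the number is now seen to respond to the aryl group on the sulfonyl as well. No measurement shown here explains why the number falls with this change.

The compounds shown leave open whether a phenyl carrying a single chlorine would hold the number, and whether methyl or methoxy groups in place of the chlorines would do the same. Compound 3 cannot settle this, since its sulfonyl aryl group is not the only place where it differs from compound 1.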